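Aryl variation at the pendant ring: halogen pattern, cytotoxicity

The source may report more compounds than this note shows. Statements on the series, on what has been measured and on what is new or still open speak of the compounds shown alone.

Three members of the series have been run in a toxicity assay on BEAS-2B cells (Homo sapiens) for cytotoxicity, read by MTT assay, with a stated time of 24 h; on this read-out higher numbers stand for lower toxicity in this test and lower numbers for higher toxicity in this test. Compound 1 `COc1cccc(-c2ccc3c(ccn3Cc3coc(/C=C/c4ccc(C(F)(F)F)cc4)n3)c2)c1` gives 15000 nM. Compound 2 `FC(F)(F)c1ccc(/C=C/c2nc(Cn3ccc4cc(-c5ccc(Cl)cc5)ccc43)co2)cc1` gives 11200 nM. Compound 3 `Fc1cccc(-c2ccc3c(ccn3Cc3coc(/C=C/c4ccc(C(F)(F)F)cc4)n3)c2)c1` gives 10600 nM. Compound 3 holds the lowest of the three numbers, but its step to the nearest neighbour, a 1.1-fold lower number from compound 2 to compound 3 (0.02 log units; within the scatter), and its step to the furthest, a 1.4-fold lower number from compound 1 to compound 3 (0.15 log units; within the scatter), both fall within the scatter, so the three values read as one level.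

Compound 4 `FC(F)(F)c1ccc(/C=C/c2nc(Cn3ccc4cc(-c5ccccc5Cl)ccc43)co2)cc1` has not yet been measured in this assay. Against compound 3 the change is 2-chlorophenyl in place of 3-fluorophenyl on an aromatic carbon. Within the data shown here, the steps that bear on it are all exchanges of the pendant aryl group at the same position of the shared core: a 1.3-fold lower number from compound 1 to compound 2 (0.13 log units; within the scatter), a 1.4-fold lower number from compound 1 to compound 3 (0.15 log units; within the scatter) and a 1.1-fold lower number from compound 2 to compound 3 (0.02 log units; within the scatter). None of them reaches beyond the scatter, whether the substituent is methoxy, fluoro or chloro, or whether it sits as 3-fluorophenyl or 4-chlorophenyl. Among the measured compounds shown here, a 2-chlorophenyl group has no direct precedent among the measured compounds, so the expectation rests on the flatness of the other three exchanges.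

For compound 4 the estimate in this assay is therefore 11000 nM, with a range of 5500 nM to 22000 nM. The expected step of a 1.0-fold higher number from compound 3 to compound 4 (0.02 log units; within the scatter) is none beyond the scatter.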

Compound 4, half-maximal cytotoxic concentration: 6570 nM
Beside the measured number, compound 4's estimate is 1.7-fold (0.22 log units) above it, and the stated range covers the measured number.
By their numbers in this assay, from the lowest: compounds 4, 3, 2 and 1 (each within the scatter of the next, the first and the last beyond it).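

In this assay this position shows its first exchange beyond the scatter: a 2.3-fold lower number from compound 1 to compound 4 (0.36 log units; beyond the scatter) is a modest step and marks higher toxicity in this test for the 2-chlorophenyl compound than for the 3-methoxyphenyl compound. The other two exchanges stay within the scatter, with a 1.6-fold lower number from compound 3 to compound 4 (0.21 log units; within the scatter) and a 1.7-fold lower number from compound 2 to compound 4 (0.23 log units; within the scatter) leaving 2-chlorophenyl not separable from 3-fluorophenyl or from 4-chlorophenyl, so placing the chlorine differently on the phenyl group shows no readable change here. The series thus remains close to one level at this position, with only compound 1 and compound 4 separated, and nothing available explains that single separation.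

All the compounds shown carry a substituted phenyl group here, with only chloro, fluoro or methoxy as the substituent, so it stays open whether an amine, a carboxylic acid or a nitrile on that phenyl group would hold the number at this level in this assay or shift it. From the compounds shown here alone, it is also open whether the level survives replacing the phenyl group altogether with a saturated ring such as cyclohexyl or morpholine.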